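From oxan-2-yl to oxolan-2-yl in compound 1

The source may report more compounds than this note shows. Statements on the series, on what has been measured and on what is new or still open speak of the compounds shown alone.

In an ADME assay on MCF7 cells (Homo sapiens) for cytotoxicity, with a stated time of 72 h (on this read-out higher numbers stand for weaker inhibition and lower numbers for stronger inhibition), compound 1 (`Oc1ccccc1CNc1ncnc2c1ncn2C1CCCCO1`) gives > 100000 nM as a limit of the assay. Compound 2 (`Oc1cccc(CNc2ncnc3c2ncn3C2CCCCO2)c1O`) gives > 100000 nM as a limit too. For the measured compounds named here, both values sit at the same limit (the limit of > 100000 nM in this assay, at which 2 of the 2 values shown sit) and the one measured step (a step that the two limits leave unreadable from compound 1 to compound 2) has no readable size. Compound 3 (`Oc1ccccc1CNc1ncnc2c1ncn2C1CCCO1`) carries oxolan-2-yl in place of oxan-2-yl on an aromatic nitrogen. That measured step offers no size to carry over, so no step beyond the scatter is expected in this assay (a number no higher from compound 1 to compound 3 (the limit leaves the size open)). For compound 3 the estimate is 100000 nM with an expected range of 50000 nM to 200000 nM in this read-out.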

Compound 3, half-maximal inhibitory concentration: > 100000 nM
Compound 3: only a limit was reported; the forecaster's own chance of this, stated with the estimate: 85%; the middle value sits exactly at the limit.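

Compound 3 gives > 100000 nM, again a limit, so no step from compound 1 to compound 3 can be read: the limit of > 100000 nM in this assay, at which 3 of the 3 values shown sit.

The compounds shown leave open whether oxolan-2-yl in place of oxan-2-yl changes the read-out at all.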